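A few compounds are considered here, and "the series" means these few. Any claim that something is new, unique, unknown or untested is made for them only; others in the source may bear on it.

The study follows four compounds built on one shared core. Compound 1 `Nc1cccc(CCCCCC(=O)N2CCOC2=O)c1` and compound 2 `Nc1ccc(CCCCCC(=O)N2CCOC2=O)cc1` both carry an amino group; how their two cores differ is not broken down here. In an assay on HEK293 cells for inhibition of N-acylethanolamine-hydrolyzing acid amidase (Rattus norvegicus), read by LC-MS, with a stated time of 30 min (on this read-out lower numbers stand for stronger inhibition and higher numbers for weaker inhibition), compound 1 gives only a limit, > 20000 nM. This value is the limit of > 20000 nM in this assay, at which 1 of the 3 values shown sits. In this assay compound 2 gives 15700 nM. Compound 3 `O=C(CCCCCc1cccc(C(F)(F)F)c1)N1CCOC1=O` arises from compound 1 through (trifluoromethyl in place of amino on an aromatic carbon), and in this assay compound 3 gives 58 nM, a step of an at least 340-fold lower number from compound 1 to compound 3 (2.53 log units; beyond the scatter). Compound 4 `O=C(CCCCCc1ccc(C(F)(F)F)cc1)N1CCOC1=O`, not yet measured, arises from compound 2 through the same kind of change, (trifluoromethyl in place of amino on an aromatic carbon), the group now sitting para to a large group rather than meta to a large group. Resting on compound 3, whose step an at least 340-fold lower number from compound 1 to compound 3 (2.53 log units; beyond the scatter) was large, the expected step in this assay is a 160-fold lower number from compound 2 to compound 4 (2.20 log units; beyond the scatter). Compound 4 is therefore estimated at 100 nM, between 25 nM and 500 nM.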

Compound 4, half-maximal inhibitory concentration: 1040 nM
Beside the measured number, compound 4's estimate is 10-fold (1.02 log units) below it; measured number above the stated range.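

In this assay, trifluoromethyl in place of amino gives a 15-fold lower number from compound 2 to compound 4 (1.18 log units; beyond the scatter), so the direction of the change carries over to the core of compound 2, but its size does not: the same change on two cores in this assay, an at least 340-fold lower number (2.53 log units; beyond the scatter) from compound 1 to compound 3 and a 15-fold lower number (1.18 log units; beyond the scatter) from compound 2 to compound 4, at least 22-fold (1.35 log units) apart, beyond the scatter of two such steps. Compound 1 gives only a limit, so the earlier step has no exact size: the limit of > 20000 nM in this assay, at which 1 of the 4 values shown sits. For the compounds shown here, with only two pairs, the shared direction holds for these cores alone, and the data do not show what sets the size of the step.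

The compounds shown leave open whether a chlorine, a methoxy group or a nitrile in place of amino would follow the same course on these cores. Also open, on these data alone, is how a shorter or longer chain would alter the step.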